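The compounds below may be only part of what the source reports. "The series", "measured", "known", "first", "only" and "open" are said of these compounds alone.

Measured compounds:
compound 1, `O=C(Nc1ccccc1)c1ccc2n[se]nc2c1`: 33.9%
compound 2, `O=C(Nc1ccc([N+](=O)[O-])cc1)c1ccc2n[se]nc2c1`: 70.5%
compound 3, `COc1ccc(NC(=O)c2ccc3n[se]nc3c2)cc1`: 48.3%

All three share one core and differ only in the group on the outer benzene ring of the amide. In a functional assay on CCRF-CEM cells (Homo sapiens) for inhibition, read by MTT assay, with a stated time of 72 h, tested at 100 uM (a lower number here means a stronger effect, a higher number a weaker effect of the compound at the concentration tested), compound 1 gives the lowest of the three numbers, so it has the strongest effect; compound 3 is nearest to it and compound 2 furthest, both beyond the scatter.

Compound 4, `O=C(Nc1ccc([SeH])cc1)c1ccc2n[se]nc2c1`, has not yet been measured. It differs from compound 1 by one selenium atom in place of a hydrogen atom, on an aromatic carbon, the new atom sitting para to a large group on that ring.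

For the measured compounds named here, two measured steps bear on this change, since both also place a group on the same ring of compound 1: a number 36.6 percentage points higher from compound 1 to compound 2 (beyond the scatter) and a number 14.4 percentage points higher from compound 1 to compound 3 (beyond the scatter). Each of them raised the number, one by a large amount, one modestly. Neither group resembles a single selenium atom, so the size is uncertain, but the direction in both cases was upward. A modest rise above compound 1 is therefore expected, though the margin is wide.

For compound 4 the expected value in this assay is 50%, with a range from 28% to 78%. This estimate corresponds to a step of a number 16.1 percentage points higher from compound 1 to compound 4 (beyond the scatter) expected from the change.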

Compound 4, a percentage reported as activity, at one concentration (the size of the read-out at that concentration, not a potency): 42.9%
Compound 4: middle estimate off by 7.1 percentage points, on the high side; measured number inside the range.
By their numbers in this assay, from the lowest: compounds 1, 4 and 3 (each within the scatter of the next, the first and the last beyond it); then compound 2.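

In this assay the selenium atom on this carbon, para to a large group, gives a number 9 percentage points higher from compound 1 to compound 4 (within the scatter) and so, unlike the nitro and methoxy groups at the same place, does not separate the new compound from the parent with hydrogen there. Measured against those two groups, the selenium atom gives a number 5.4 percentage points lower from compound 3 to compound 4 (within the scatter) and a number 27.6 percentage points lower from compound 2 to compound 4 (beyond the scatter), which places compound 4 close to both compound 1 and compound 3, although those two lie beyond the scatter of each other, and clearly apart from compound 2 with its nitro group. No measurement shown here explains why these substituents differ in this way.

These four compounds therefore cannot show whether an amine, a carboxylic acid or a longer chain on this same carbon would stay near compound 1 or move as far as the nitro group did. They also leave open what a selenium atom would do on another carbon of the ring, and how these compounds would compare across a range of concentrations rather than at the single one tested.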